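The source may report more compounds than this note shows. Statements on the series, on what has been measured and on what is new or still open speak of the compounds shown alone.

Compound 1 `C[C@H](c1ccc(F)cc1)N(Cc1cccc(C(=O)O)c1)C(=O)c1cc2ccccn2n1`: 94 nM
Compound 2 `C[C@H](c1ccc(F)cc1)N(Cc1cccc(C(=O)O)c1)C(=O)c1cc2ccccc2nn1`: 340 nM
Compound 3 `C[C@H](c1ccc(F)cc1)N(Cc1cccc(C(=O)O)c1)C(=O)c1cn2ccccc2n1`: 307 nM

These three compounds share a core and differ only in the bicyclic aromatic group on the carbonyl carbon. In an assay on CHO T-rex cells for antagonist activity at transient receptor potential cation channel subfamily M member 8 (Homo sapiens), read by calcium flux, with a stated time of 20 min (on this read-out higher numbers stand for weaker inhibition and lower numbers for stronger inhibition), compound 3 gives 307 nM, the second highest of the three numbers. Its nearest neighbour is compound 2, and the pair lie within the scatter: a 1.1-fold lower number from compound 2 to compound 3 (0.04 log units; within the scatter). The furthest is compound 1, which stands lower: a 3.3-fold higher number from compound 1 to compound 3 (0.51 log units; beyond the scatter).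

Compound 4 `C[C@H](c1ccc(F)cc1)N(Cc1cccc(C(=O)O)c1)C(=O)c1cc2ccccc2cn1` is not yet measured. It arises from compound 3 by a group of 10 heavy atoms (9 carbon, 1 nitrogen; one six-membered aromatic ring of carbon only, one six-membered aromatic ring with 1 hetero atom) in place of a group of 9 heavy atoms (7 carbon, 2 nitrogen; one five-membered aromatic ring with 2 hetero atoms, one six-membered aromatic ring with 1 hetero atom), on a carbonyl carbon. All three measured steps bear on this kind of exchange, since each swaps the bicyclic group on the same carbonyl carbon: a 3.6-fold higher number from compound 1 to compound 2 (0.56 log units; beyond the scatter), a 3.3-fold higher number from compound 1 to compound 3 (0.51 log units; beyond the scatter), and the step within the scatter from compound 2 to compound 3. Two of the three exchanges moved the number modestly, one not at all beyond the scatter, so for compound 4 a modest step in this assay in either direction, or none beyond the scatter, is expected; the data give no ground to favour a direction. Compound 4 is therefore estimated at 350 nM, with a range from 110 nM to 1100 nM, the expected step being a 1.1-fold higher number from compound 3 to compound 4 (0.06 log units; within the scatter).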

Compound 4, half-maximal inhibitory concentration in the transient receptor potential cation channel subfamily M member 8 assay: 90 nM
Estimate against measurement, compound 4: 3.9-fold (0.59 log units) above, and the stated range ends above it.
By their numbers in the transient receptor potential cation channel subfamily M member 8 assay, from the lowest: compounds 4 and 1 (each within the scatter of the next); then compounds 3 and 2 (each within the scatter of the next).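

In the transient receptor potential cation channel subfamily M member 8 assay, the isoquinolin-3-yl group on the carbonyl carbon matches the group of compound 1, with a 1.0-fold lower number from compound 1 to compound 4 (0.02 log units; within the scatter), so a group with no five-membered ring can stand level with that compound. Ring size alone does not set the number here: compound 2 and compound 4 both carry one six-membered aromatic ring of carbon only, yet there is a 3.8-fold lower number from compound 2 to compound 4 (0.58 log units; beyond the scatter). In the transient receptor potential cation channel subfamily M member 8 assay the exchange also gives a 3.4-fold lower number from compound 3 to compound 4 (0.53 log units; beyond the scatter), and the same exchange shifts the reading in a physicochemical assay for lipophilicity; on this read-out higher numbers stand for higher lipophilicity and lower numbers for lower lipophilicity: the measured distribution coefficient of compound 3, 0.6, and of compound 4, 1.1, a number 0.50 log units higher (beyond the scatter)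

In the physicochemical assay compound 3 gives 0.6 and compound 4 gives 1.1 as measured. This single pair cannot tell whether the two read-outs are linked across the series. It also leaves open how an amine or a methoxy group on the isoquinolin-3-yl group would move the number.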